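This account rests on a few compounds, and the source may have more. Where it says the series, first, only, none or still open, it means among the compounds named here.

Measured so far in a physicochemical assay for solubility, read by mass spectrometry, in phosphate buffer, with a stated time of 24 h, at pH 7.4; on this read-out lower numbers stand for lower solubility and higher numbers for higher solubility:
- compound 1 `Cc1occc1C(=O)N1CCC(NC(=O)Nc2ccc(OC(F)(F)F)cc2)CC1`: 8.6 ug/mL
- compound 2 `Cc1ccoc1C(=O)N1CCC(NC(=O)Nc2ccc(C(F)(F)F)cc2)CC1`: 0.8 ug/mL

Only these two numbers are available. Compound 2, at 0.8 ug/mL, is the lower of them, and compound 1, at 8.6 ug/mL, lies above it by more than the scatter. The two compounds differ in more than one place, so their gap cannot be assigned to any single change.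

The next compound is compound 3 `O=C(Nc1ccc(C(F)(F)F)cc1)NC1CCN(C(=O)[C@@H]2CCOC2)CC1`. Relative to compound 2 the change is oxolan-3-yl in place of 3-methylfuran-2-yl on a carbonyl carbon. In words, oxolan-3-yl stands in place of 3-methylfuran-2-yl on a carbonyl carbon, so a five-membered non-aromatic ring with 1 defined stereocentre replaces a five-membered aromatic ring. The rest of compound 2 stays as it is.

Among the compounds with values here, no measured pair isolates this change, so the expectation is a judgement on the structural change alone and carries a wide range. An upward move beyond the scatter is expected in this assay, with the estimated size of a 15-fold higher number from compound 2 to compound 3 (1.18 log units; beyond the scatter). For compound 3 the expected value is 12 ug/mL, with an estimated range of 3 ug/mL to 50 ug/mL.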

Compound 3, solubility: 1.4 ug/mL
Compound 3: middle estimate off by 8.6-fold (0.93 log units), on the high side; the whole stated range lies above it.
By their numbers in this assay, from the lowest: compounds 2 and 3 (each within the scatter of the next); then compound 1.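

In this assay, within the data shown here, oxolan-3-yl in place of 3-methylfuran-2-yl on a carbonyl carbon gives a 1.8-fold higher number from compound 2 to compound 3 (0.24 log units; within the scatter) as the first step that isolates a single place. On this core, therefore, a five-membered non-aromatic ring with 1 defined stereocentre and a five-membered aromatic ring, each with 1 hetero atom, give numbers that this read-out does not separate, and the exchange of one for the other does not by itself account for the gap seen earlier between the two first compounds. No measurement at hand explains why the two numbers lie so close.

Open, from the compounds shown here alone, is whether any other group on this carbonyl carbon, such as a longer chain ending in an amine or a carboxylic acid, would stand apart from compound 3 by more than the scatter. Also open, going by these compounds, are whether the other stereoisomer of the oxolan-3-yl compound reads alike and whether the same exchange gives a similar step when the trifluoromethoxy group of compound 1, at 8.6 ug/mL, replaces the trifluoromethyl group.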